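The source may report more compounds than this note shows. Statements on the series, on what has been measured and on what is new or still open speak of the compounds shown alone.

Compound 1 `NC(=S)N/N=C(/COc1ccc(Br)cc1)c1ccccc1`, compound 2 `COc1ccc(/C(COc2ccc(Br)cc2)=N\NC(N)=S)cc1` and compound 3 `NC(=S)N/N=C(\COc1ccccc1)c1ccc(Br)cc1` were all tested in an ADME assay on L929 cells (Mus musculus) for cytotoxicity, read by resazurin assay, with a stated time of 96 h; a lower number here means that less compound is tolerated, a higher number that more compound is tolerated. Compound 1 gives only a limit of the assay, < 27500 nM. Compound 2 likewise gives only a limit, < 25400 nM. For the measured compounds named here, compound 3 gives 54900 nM, the only full number among the three.

Compound 2 differs from compound 1 by methoxy in place of hydrogen on an aromatic carbon. The step that the two limits leave unreadable from compound 1 to compound 2 cannot be read because the limit of < 27500 nM in this assay, at which 1 of the 3 values shown sits, and the limit of < 25400 nM in this assay, at which 1 of the 3 values shown sits, bound both values rather than fixing them.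

Compound 4 `COc1cccc(OC/C(=N\NC(N)=S)c2ccc(Br)cc2)c1` has not yet been measured. It differs from compound 3 by methoxy in place of hydrogen on an aromatic carbon. Compound 3 and compound 1 are built from the same atoms joined differently, and the difference between the two cores is not broken down here. The change from compound 3 to compound 4 is therefore the same kind of change as from compound 1 to compound 2, not the same: in compound 2 the methoxy sits para to a large group, in compound 4 it sits meta to a large group.

Because the step that the two limits leave unreadable from compound 1 to compound 2 has no readable size, the expectation for this assay rests mainly on compound 3 with its measured 54900 nM. The expected step is a 1.1-fold lower number from compound 3 to compound 4 (0.04 log units; within the scatter) in this assay, taken as small. Compound 4 is thus expected to give about 50000 nM, with 25000 nM to 110000 nM as the likely range.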

Compound 4, half-maximal cytotoxic concentration: 50700 nM
The estimate for compound 4 lay 1.0-fold (0.01 log units) below the measured number; the measured number falls inside the stated range.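

In this assay, methoxy in place of hydrogen on an aromatic carbon, here meta to a large group, gives a 1.1-fold lower number from compound 3 to compound 4 (0.03 log units; within the scatter). On the core of compound 3, then, this replacement leaves no difference that can be told apart from the ordinary spread of repeated measurements. The same kind of replacement on the core of compound 1 cannot be read, as compound 1 and compound 2 each give only a limit of the assay and not a number, and one readable step on a single core does not show that the methoxy change carries over from one core to the other.

The compounds shown leave open whether an amine, a carboxylic acid or a longer chain such as propoxy at this aromatic carbon of the core of compound 3 would read as closely to the hydrogen compound as the methoxy does. They also leave open how large any step on the core of compound 1 really is, and a comparison there would need full numbers for both partners in this assay.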